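Methoxy for Methyl on the Anilide Ring

The source may hold more compounds than are shown below. What is called first, only, known or untested is meant among the compounds shown, and "the series" means these compounds.

In an assay for inhibition of Amine oxidase [flavin-containing] B (Mus musculus), read by fluorescence, with a stated time of 30 min, in the presence of a further agent that is not named here (a lower number here means a stronger inhibitor, a higher number a weaker inhibitor), compound 2 `Cc1ccc(C(=O)Nc2cccc(-c3nc4c(c(=O)n(C)c(=O)n4C)n3C)c2)cc1` gives 3560 nM, and compound 1 `COc1ccc(C(=O)Nc2cccc(-c3nc4c([nH]3)c(=O)n(C)c(=O)n4C)c2)cc1` gives 3490 nM; the two numbers lie within the usual scatter of each other, so neither stands apart. Compound 3 `COc1ccc(C(=O)Nc2cccc(-c3nc4c(c(=O)n(C)c(=O)n4C)n3C)c2)cc1` has not been measured. It differs from compound 2 in one place: methoxy in place of methyl on an aromatic carbon. Within the data shown here, no measured pair shows this change on its own, so no measured step guides it, and no step beyond the scatter is expected in this assay. Compound 3 is therefore expected to give 3500 nM, within 1500 nM to 8000 nM. The step of a 1.0-fold lower number from compound 2 to compound 3 (0.01 log units; within the scatter) that this estimate means is expected to stay within the scatter.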

Compound 3, inhibition constant: 3920 nM
The estimate for compound 3 lay 1.1-fold (0.05 log units) below the measured number; low and high end bracket the measured number.
By their numbers in this assay, from the lowest: compounds 1, 2 and 3 (each within the scatter of the next).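

The exchange of methyl for methoxy on the aromatic ring, para to a large group, comes with a 1.1-fold higher number from compound 2 to compound 3 (0.04 log units; within the scatter) in this assay, so at this position the added oxygen moves the number no further than the scatter. With the 4-methoxyphenyl group held fixed, methyl in place of hydrogen on the aromatic nitrogen comes with a 1.1-fold higher number from compound 1 to compound 3 (0.05 log units; within the scatter), also within the scatter. Nothing measured here accounts for either result.

From the compounds shown here alone, whether an amine or a carboxylic acid at that ring position would shift the number stays open. So does the effect of a longer chain on the aromatic nitrogen.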